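The source may hold more compounds than are shown below. What is called first, only, known or untested is meant among the compounds shown, and "the series" means these compounds.

Measured so far:
- compound 1, `COc1cc(/C=C/C(=O)c2cccc(-n3cc(-c4ccccc4)[nH]c3=O)c2)cc(OC)c1OC`, 2020 nM
- compound 2, `COc1ccc(-c2cn(-c3cccc(C(=O)/C=C/c4ccc(O)c(OC)c4)c3)c(=O)[nH]2)cc1`, 8200 nM

Both numbers come from a functional assay on NCI-H322M cells (Homo sapiens) for inhibition (on this read-out lower numbers stand for stronger inhibition of growth and higher numbers for weaker inhibition of growth), and compound 2 gives the higher of the two, so it is the weaker inhibitor of the pair; its gap to compound 1 lies beyond the scatter of repeated measurements.

Compound 3, `COc1ccc(-c2cn(-c3cccc(C(=O)/C=C/c4cc(OC)c(OC)c(OC)c4)c3)c(=O)[nH]2)cc1`, has not been measured. It differs from compound 2 in one place: 3,4,5-trimethoxyphenyl in place of 4-hydroxy-3-methoxyphenyl on a double-bonded chain carbon bound to a double-bonded chain carbon. The two share the rest of their structure, including the 4-methoxyphenyl group on the core. Compound 1, which also carries the 3,4,5-trimethoxyphenyl group on its chain, gives 2020 nM in this assay, the stronger of the two measured results. On that basis a step toward stronger inhibition is expected, though without a measured pair for this exact exchange its size is uncertain.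

Compound 3 is estimated at 3200 nM in this assay, with a likely range from 1000 nM to 10000 nM, an expected step of a 2.6-fold lower number from compound 2 to compound 3 (0.41 log units; beyond the scatter).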

Compound 3, concentration for 50% growth inhibition: 2660 nM
Compound 3: middle estimate off by 1.2-fold (0.08 log units), on the high side; the range from low to high includes it.
By their numbers in this assay, from the lowest: compounds 1 and 3 (each within the scatter of the next); then compound 2.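

In this assay, within the data shown here, this is the first pair differing in one place, and 3,4,5-trimethoxyphenyl in place of 4-hydroxy-3-methoxyphenyl on a double-bonded chain carbon bound to a double-bonded chain carbon gives a 3.1-fold lower number from compound 2 to compound 3 (0.49 log units; beyond the scatter), so this exchange strengthens inhibition of growth. By contrast, methoxy in place of hydrogen on an aromatic carbon gives a 1.3-fold higher number from compound 1 to compound 3 (0.12 log units; within the scatter), so that exchange has no effect that can be told apart from the scatter. Among these compounds, of these two exchanges, only the one on the chain moves the number clearly.

The compounds shown leave open which of the methoxy groups on the chain's ring matter most, and whether an amine or a carboxylic acid on that ring would keep inhibition of growth. No measurement here explains the step between compound 2 and compound 3.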